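Substituent Swap on the Five-Membered Ring: Efficacy Outlook

This account rests on a few compounds, and the source may have more. Where it says the series, first, only, none or still open, it means among the compounds named here.

Measured compounds:
compound 1, `CC(C)(C)[C@H](C(=O)Nc1ncc(C(F)(F)F)s1)c1ccc(Cl)cc1`, 95%
compound 2, `CSc1cnc(NC(=O)[C@H](c2ccc(Cl)cc2)C(C)(C)C)s1`, 109%

In a functional assay on CHO cells for agonist activity at Free fatty acid receptor 2 (Homo sapiens), read by cAMP accumulation (on this read-out higher numbers stand for larger maximal responses and lower numbers for smaller maximal responses), compound 2 holds the higher of the two numbers, the step of a number 14 percentage points higher from compound 1 to compound 2 (beyond the scatter) lying beyond the scatter. Compound 3, `CN(C)c1cnc(NC(=O)[C@H](c2ccc(Cl)cc2)C(C)(C)C)s1`, differs from compound 2 by dimethylamino in place of methylsulfanyl on an aromatic carbon. Among the compounds with values here, no measured step involves a dimethylamino group; the single step of a number 14 percentage points higher from compound 1 to compound 2 (beyond the scatter) shows only that exchanging the group on this aromatic carbon can move the maximal response modestly. Compound 3 is therefore expected to show a step of a number 9 percentage points lower from compound 2 to compound 3 (within the scatter), within the scatter. The estimate for compound 3 in this assay is 100%, between 75% and 120%.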

Compound 3, largest response reached (reported as efficacy), in percent of the reference or control that the assay uses: 112%
Beside the measured number, compound 3's estimate is 12 percentage points below it; low and high end bracket the measured number.
By their numbers in this assay, from the lowest: compound 1; then compounds 2 and 3 (each within the scatter of the next).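

In this assay, the carbon next to the ring sulfur accepts dimethylamino in place of methylsulfanyl with a number 3 percentage points higher from compound 2 to compound 3 (within the scatter) and so no real change in maximal response. Set against trifluoromethyl, dimethylamino gives a number 17 percentage points higher from compound 1 to compound 3 (beyond the scatter) and so joins methylsulfanyl above compound 1, showing that a group attached through nitrogen serves here as well as one attached through sulfur. No measurement at hand gives a reason for this pattern.

Going by these compounds, whether a primary amine, a methoxy group or a longer chain such as butylsulfanyl on this carbon would hold the response at this level remains open.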